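Same Chloro Step on a Methyl-Bearing Core

The source may hold more compounds than are shown below. What is called first, only, known or untested is meant among the compounds shown, and "the series" means these compounds.

Compound 1 `CCCCCCCCc1ccc(OCC(=O)Cn2nnc(-c3ccccc3)n2)cc1` is the reference here. In an assay on microsomes from brain for inhibition of Fatty-acid amide hydrolase 1 (Rattus norvegicus), read by fluorescence and HPLC, with a stated time of 60 min (a lower number here means a stronger inhibitor, a higher number a weaker inhibitor), compound 1 gives 24 nM. Compound 2 `CCCCCCCCc1ccc(OCC(=O)Cn2nnc(-c3ccc(Cl)cc3)n2)cc1` carries the change (chloro in place of hydrogen on an aromatic carbon); compound 2 gives 35 nM, a step of a 1.5-fold higher number from compound 1 to compound 2 (0.16 log units; within the scatter). Compound 3 `CCCCCCCCc1ccc(OC(C)C(=O)Cn2nnc(-c3ccccc3)n2)cc1` differs from compound 1 by methyl in place of hydrogen on a saturated chain carbon bound to a carbonyl carbon and an oxygen on an aromatic ring, and compound 3 gives 24 nM, a step of no change at the digits printed from compound 1 to compound 3 (within the scatter). Among the measured compounds shown here, compound 4 `CCCCCCCCc1ccc(OC(C)C(=O)Cn2nnc(-c3ccc(Cl)cc3)n2)cc1` has not been measured; it differs from compound 3 by chloro in place of hydrogen on an aromatic carbon, which is the same change, at the same place, as the one from compound 1 to compound 2. Because that earlier step was a 1.5-fold higher number from compound 1 to compound 2 (0.16 log units; within the scatter), a similar small step is expected from compound 3, estimated as a 1.5-fold higher number from compound 3 to compound 4 (0.16 log units; within the scatter). Compound 4 is therefore expected to give about 35 nM in this assay, between 15 nM and 80 nM.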

Compound 4, half-maximal inhibitory concentration: 35 nM
For compound 4 middle estimate and measured number coincide at the digits printed; the measured number falls inside the stated range.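

In this assay the chloro step on the methyl-bearing core reads a 1.5-fold higher number from compound 3 to compound 4 (0.16 log units; within the scatter), and it matches the same step on the core of compound 1: the same change on two cores in this assay, a 1.5-fold higher number (0.16 log units; within the scatter) from compound 1 to compound 2 and a 1.5-fold higher number (0.16 log units; within the scatter) from compound 3 to compound 4, 1.0-fold (0.00 log units) apart, within the scatter of two such steps. The methyl step, taken with the chloro group in place, reads no change at the digits printed from compound 2 to compound 4 (within the scatter), and it too matches its earlier counterpart: the same change on two cores in this assay, no change at the digits printed (within the scatter) from compound 1 to compound 3 and no change at the digits printed (within the scatter) from compound 2 to compound 4, 1.0-fold (0.00 log units) apart, within the scatter of two such steps. Among the compounds shown here, both changes therefore carried over unaltered between these cores, but every step lies within the scatter, so this shows only that two small steps repeat, not how a step large enough to read clearly would carry over.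

Open, going by these compounds, is whether an amine or a carboxylic acid in place of the chloro would carry over as well. The same question stands for a longer chain in place of the methyl.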